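Aryl swap on the imine carbon: thiophene for chlorophenyl

A few compounds are considered here, and "the series" means these few. Any claim that something is new, unique, unknown or untested is made for them only; others in the source may bear on it.

In a functional assay on WM 266-4 cells (Homo sapiens) for antiproliferative activity, read by MTT assay, with a stated time of 48 h (on this read-out lower numbers stand for stronger inhibition of growth and higher numbers for weaker inhibition of growth), compound 1 `S=C(Nc1ccccc1)N1N=C(c2ccc(Br)cc2)CC1c1ccc2c(c1)OCCO2` gives 870 nM and compound 2 `Cc1ccc(C2=NN(C(=S)Nc3ccccc3)C(c3ccc4c(c3)OCCO4)C2)cc1` gives 10300 nM, a change of a 12-fold higher number from compound 1 to compound 2 (1.07 log units; beyond the scatter). Compound 3 `S=C(Nc1ccccc1)N1N=C(c2cccc(Cl)c2)CC1c1ccc2c(c1)OCCO2` reaches only the limit of this assay, > 200000 nM, as noted in the limit of > 200000 nM in this assay, at which 1 of the 3 values shown sits. On the numbers shown compound 3 is the weakest of the three, with an at least 220-fold higher number from compound 1 to compound 3 (2.36 log units; beyond the scatter) and an at least 19-fold higher number from compound 2 to compound 3 (1.28 log units; beyond the scatter). Compound 4 `S=C(Nc1ccccc1)N1N=C(c2cccs2)CC1c1ccc2c(c1)OCCO2` differs from compound 3 by thiophen-2-yl in place of 3-chlorophenyl on a carbon with a double bond to nitrogen. Both measured steps bear on this change: each replacement of the group on the carbon with a double bond to nitrogen moved this assay by a large amount, so a large step is expected here as well, most likely downward from the limit, though its size is uncertain. Compound 4 is estimated at 30000 nM, range 3000 nM to 200000 nM, an expected step of an at least 6.6-fold lower number from compound 3 to compound 4 (0.82 log units; beyond the scatter).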

Compound 4, concentration for 50% growth inhibition: 154000 nM
Compound 4: middle estimate off by 5.1-fold (0.71 log units), on the low side; low and high end bracket the measured number.
By their numbers in this assay, from the lowest: compound 1; then compound 2; then compound 4. At a limit, above all of these: compound 3.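

Compound 3 stands at a limit of the assay, so the step of an at least 1.2-fold lower number from compound 3 to compound 4 (0.11 log units; that floor lies within the scatter) is only a floor and shows no gain for thiophen-2-yl over 3-chlorophenyl. In this assay the steps of a 15-fold higher number from compound 2 to compound 4 (1.17 log units; beyond the scatter) and a 180-fold higher number from compound 1 to compound 4 (2.25 log units; beyond the scatter) place thiophen-2-yl well behind both 4-methylphenyl and 4-bromophenyl on the carbon with a double bond to nitrogen. A five-membered aromatic ring therefore does not recover the numbers of compound 1 or compound 2 here.

Open, on these data alone, is whether a 4-aminophenyl or 4-methoxyphenyl group on this carbon would match 4-bromophenyl. Also open, as far as these compounds go, is whether a bromo group on the thiophene would bring the number down.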